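A few compounds are considered here, and "the series" means these few. Any claim that something is new, unique, unknown or untested is made for them only; others in the source may bear on it.

Working notes on the series. Compound 1 `O=C(Nc1cc(-c2ccccn2)n[nH]1)N1CCC(Oc2ccccn2)CC1` and compound 2 `O=C(Nc1cc(-c2ccccn2)n[nH]1)N1CCN(c2ccc(F)cc2)CC1` share the same core and have each been tested in an ADME assay on MRC5 cells (Homo sapiens) for cytotoxicity, read by fluorescence and resazurin assay, with a stated time of 3 days; on this read-out higher numbers stand for lower toxicity in this test and lower numbers for higher toxicity in this test. In this assay compound 1 gives > 63000 nM, which is a limit of the assay and not a number. Compound 2 in this assay likewise gives > 64000 nM, again a limit rather than a number. Compound 1 therefore stands at the limit of > 63000 nM in this assay, at which 1 of the 2 values shown sits. Within the data shown here, the one further value shown is also a limit, namely (the limit of > 64000 nM in this assay, at which 1 of the 2 values shown sits). Among the measured compounds shown here, no measured step between compounds that differ in one place is available in this assay. Compound 3 `N#Cc1ccc(C2CCN(C(=O)Nc3cc(-c4ccccn4)n[nH]3)CC2)cc1` is the next member to be tested; it differs from compound 1 by 4-cyanophenyl in place of (pyridin-2-yl)oxy on a saturated ring carbon. No step beyond the usual scatter is expected for this change, and the expected step is an at least 1.0-fold lower number from compound 1 to compound 3 (0.02 log units; that floor lies within the scatter). For compound 3 in this assay the estimated value is 60000 nM, in an expected range from 20000 nM to 120000 nM.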

Compound 3, half-maximal cytotoxic concentration: > 64000 nM
Compound 3 gave a limit, no number; the forecaster's own chance of this, stated with the estimate: 65%; middle value at least 1.0-fold (0.02 log units) away from the limit.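

No step can be read from compound 1 to compound 3: in this assay each stands at a limit of the assay, not a number. The compounds shown leave open whether 4-cyanophenyl in place of (pyridin-2-yl)oxy changes this read-out at all.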